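Acetamido for pyrrolidin-1-yl: notes on compound 3

The source may hold more compounds than are shown below. What is called first, only, known or untested is meant among the compounds shown, and "the series" means these compounds.

Of the compounds shown here, two carry numbers so far. In a functional assay on aorta (Rattus norvegicus, strain Sprague-Dawley) (a lower number here means that less compound is needed, a higher number that more compound is needed for the effect), compound 1 (`Cc1ccccc1COc1nc2c(cc1-c1nc(N)cc(N)n1)c(C)nn2-c1ccccc1`) gives 290 nM and compound 2 (`Cc1nn(-c2ccccc2)c2nc(OCc3ccccc3F)c(-c3nc(N)c(N4CCCC4)c(N)n3)cc12`) gives 12700 nM as its value. Compound 2 therefore stands at the higher of the two numbers, and its gap to compound 1 lies beyond the scatter. The two structures differ in more than one place, so that gap cannot be assigned to any single change.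

Compound 3 (`CC(=O)Nc1c(N)nc(-c2cc3c(C)nn(-c4ccccc4)c3nc2OCc2ccccc2F)nc1N`) comes from compound 2 by one change: acetamido in place of pyrrolidin-1-yl on an aromatic carbon, ortho to two amino groups (acetamido in place of pyrrolidin-1-yl on an aromatic carbon). Going by the values given here, no measured step covers this change. Among the compounds with values here, the only pointer is compound 1 (290 nM), which carries neither group at that place. A move toward a lower number in this assay is expected, beyond the scatter but with wide uncertainty. The expectation is an 8.5-fold lower number from compound 2 to compound 3 (0.93 log units; beyond the scatter) for this change. The estimated value for compound 3 is 1500 nM (expected range 300 nM to 7000 nM).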

Compound 3, half-maximal effective concentration: 930 nM
Estimate against measurement, compound 3: 1.6-fold (0.21 log units) above; the measured number falls inside the stated range.
By their numbers in this assay, from the lowest: compound 1; then compound 3; then compound 2.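

In this assay, the position on an aromatic carbon, ortho to two amino groups, responds strongly to the group it carries: acetamido in place of pyrrolidin-1-yl gives a 14-fold lower number from compound 2 to compound 3 (1.14 log units; beyond the scatter), and this step is the series' only single-place comparison so far. With the rest of compound 2 unchanged, the exchange removes a five-membered non-aromatic ring and brings in a hydrogen-bond donor and a double bond outside aromatic rings, but the step cannot separate these differences. Nothing at hand bears on the cause of the step.

As far as these compounds go, it remains open which feature of acetamido goes with the lower number, and whether the trend extends to a plain amino group, a morpholine ring or a longer acyl group such as propionamido at this position. Compound 1 carries neither acetamido nor pyrrolidin-1-yl at that place but also differs from compound 2 and compound 3 elsewhere, so the effect of leaving the position without either group also remains unresolved.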